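The source may report more compounds than this note shows. Statements on the series, on what has been measured and on what is new or still open speak of the compounds shown alone.

Working notes on the series. Compound 1 `Cc1cc(F)c(S(C)(=O)=O)cc1C(=O)N=C(N)N` sits second highest of the three numbers in a functional assay for inhibition of sodium/hydrogen exchanger (Oryctolagus cuniculus) (a lower number here means a stronger inhibitor, a higher number a weaker inhibitor), where compound 1 gives 44 nM. Compound 2 `Cc1cc(Br)c(S(C)(=O)=O)cc1C(=O)N=C(N)N` gives 12 nM in this assay, and compound 3 `Cc1cc(-c2ccc(Cl)cc2)c(S(C)(=O)=O)cc1C(=O)N=C(N)N` gives 45 nM. The steps between them: a 3.7-fold lower number from compound 1 to compound 2 (0.56 log units; beyond the scatter); a 1.0-fold higher number from compound 1 to compound 3 (0.01 log units; within the scatter); a 3.8-fold higher number from compound 2 to compound 3 (0.57 log units; beyond the scatter).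

Compound 4 `Cc1cc(Sc2cccc(Cl)c2)c(S(C)(=O)=O)cc1C(=O)N=C(N)N` has not yet been measured. Relative to compound 1 the change is (3-chlorophenyl)sulfanyl in place of fluoro on an aromatic carbon. Within the data shown here, two measured steps bear on it. The step of a 1.0-fold higher number from compound 1 to compound 3 (0.01 log units; within the scatter) shows that a 4-chlorophenyl entering in place of fluoro at this carbon leaves the number essentially unmoved. The step of a 3.7-fold lower number from compound 1 to compound 2 (0.56 log units; beyond the scatter) shows that bromo in place of fluoro gives a modest gain. The entering (3-chlorophenyl)sulfanyl resembles the 4-chlorophenyl of compound 3 more than the bromo of compound 2, so the expectation is for no step beyond the scatter in this assay, with a mild gain possible. The expected step is a 1.3-fold lower number from compound 1 to compound 4 (0.10 log units; within the scatter). For compound 4 the estimate in this assay is 35 nM, in the range 12 nM to 100 nM.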

Compound 4, half-maximal inhibitory concentration: 37 nM
Compound 4: the middle estimate sits 1.1-fold (0.02 log units) below what was measured; the measured number falls inside the stated range.
By their numbers in this assay, from the lowest: compound 2; then compounds 4, 1 and 3 (each within the scatter of the next).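

Working notes, continued. In this assay the (3-chlorophenyl)sulfanyl group, on the aromatic carbon ortho to a methylsulfonyl group, is matched with fluoro (a 1.2-fold lower number from compound 1 to compound 4 (0.08 log units; within the scatter)) and with 4-chlorophenyl (a 1.2-fold lower number from compound 3 to compound 4 (0.09 log units; within the scatter)), so a second aryl-bearing group, this time joined through sulfur, leaves the number within the scatter. Bromo alone stands apart among the four groups at this carbon (a 3.1-fold higher number from compound 2 to compound 4 (0.49 log units; beyond the scatter)), and that step lies beyond the scatter, so compound 2 remains the only compound separated from the others. No supporting data on the cause of this pattern are available.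

Compounds 3 and 4 differ in both the sulfur link and the chlorine position, so the two changes cannot be told apart. Going by these compounds, how an amine, a carboxylic acid or a longer alkyl chain at this carbon would read remains open.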